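This account rests on a few compounds, and the source may have more. Where it says the series, first, only, none or still open, it means among the compounds named here.

Compound 1 `CCCS(=O)(=O)N1CCC(CNC(=O)C2CC2)(C(=O)N2CCOCC2)CC1`: in an ADME assay on Caco-2 cells (Homo sapiens) for permeability (on this read-out lower numbers stand for lower permeability and higher numbers for higher permeability), compound 1 gives > 22 10^-6 cm/s, which is a limit of the assay.
Compound 2 `CCCS(=O)(=O)N1CCC(CNC(=O)c2ccccc2OC(F)(F)F)(C(=O)N2CCOCC2)CC1`: in this assay compound 2 gives > 22 10^-6 cm/s, again a limit of the assay.

Compound 2 therefore stands at the upper boundary of what this assay reports, as shown by the limit of > 22 10^-6 cm/s in this assay, at which 2 of the 2 values shown sit. Among the compounds with values here, the only measured step, a step that the two limits leave unreadable from compound 1 to compound 2, cannot be sized because a step that the two limits leave unreadable from compound 1 to compound 2 joins two limits. Compound 3 `CCCS(=O)(=O)N1CCC(CNC(=O)c2c(F)ccc(Cl)c2F)(C(=O)N2CCOCC2)CC1` carries a different group on the carbonyl carbon: 3-chloro-2,6-difluorophenyl in place of 2-(trifluoromethoxy)phenyl on a carbonyl carbon. No readable step bears on this change, so compound 3 is expected to remain at the limit, with an estimated step that the limit leaves unreadable from compound 2 to compound 3, none beyond the scatter. Compound 3 is estimated at 26 10^-6 cm/s, between 15 10^-6 cm/s and 45 10^-6 cm/s.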

Compound 3, apparent permeability: > 22 10^-6 cm/s
Compound 3 was reported as a limit (the forecaster's own chance of this, stated with the estimate: 75%); the middle value does not contradict the limit.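

No step can be read among compound 1, compound 2 and compound 3, since each result is only a limit: the limit of > 22 10^-6 cm/s in this assay, at which 3 of the 3 values shown sit.

From the compounds shown here alone, whether the groups on the carbonyl carbon differ at all in this assay stays open.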